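Methylpyridyl for Fluoropyridyl on the Outer Ring

This account rests on a few compounds, and the source may have more. Where it says the series, first, only, none or still open, it means among the compounds named here.

In a functional assay for antagonist activity at Neuropeptide Y receptor type 5 (Homo sapiens) (on this read-out higher numbers stand for weaker inhibition and lower numbers for stronger inhibition), compound 2 `O=C1O[C@]2(CC[C@H](CNc3ccc(-c4ncccc4F)cn3)CC2)CN1c1cccnn1` gives 0.316 nM, the highest of the three numbers shown. Compound 1 `O=C1O[C@]2(CC[C@H](CNc3cnn(-c4ccccc4F)c3)CC2)CN1c1cccnc1F` gives 0.1 nM and compound 3 `O=C1O[C@]2(CC[C@H](CNc3cnn(-c4ccccc4F)c3)CC2)CN1c1cccnn1` gives 0.1 nM, each a lower number than compound 2 by a margin beyond the scatter. Within the data shown here, the only single-place step measured, no change at the digits printed from compound 1 to compound 3 (within the scatter), concerns the group on the amide-type nitrogen, not the position altered here. Compound 4 `Cc1cccc(-c2ccc(NC[C@H]3CC[C@]4(CC3)CN(c3cccnn3)C(=O)O4)nc2)n1` differs from compound 2 by 6-methylpyridin-2-yl in place of 3-fluoropyridin-2-yl on an aromatic carbon. Among the measured compounds shown here, no measured step touches that outer ring, so nothing anchors the change, and a 1.1-fold lower number from compound 2 to compound 4 (0.02 log units; within the scatter) is expected to stay within the scatter. Compound 4 is therefore estimated at 0.3 nM in this assay, with a range from 0.1 nM to 1 nM.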

Compound 4, inhibition constant: 0.251 nM
Compound 4: the middle estimate sits 1.2-fold (0.08 log units) above what was measured; low and high end bracket the measured number.
By their numbers in this assay, from the lowest: compounds 1 and 3 (each within the scatter of the next); then compounds 4 and 2 (each within the scatter of the next).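

In this assay the outer ring now has its first measured step: a 1.3-fold lower number from compound 2 to compound 4 (0.10 log units; within the scatter) when 6-methylpyridin-2-yl stands in place of 3-fluoropyridin-2-yl. This position therefore accepts either group with no change beyond the scatter, so the fluorine can be exchanged for a methyl on a different ring carbon without a readable effect here. Nothing available explains this outcome.

Plain pyridin-2-yl, carrying neither group, would show whether either substituent matters at all. On these data alone, how an amine or a carboxylic acid on this ring would fare remains open.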